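The source may hold more compounds than are shown below. What is called first, only, known or untested is meant among the compounds shown, and "the series" means these compounds.

Of the compounds shown here, two have been measured in a functional assay on HCT-116 cells (Homo sapiens) for inhibition, read by sulforhodamine B assay, with a stated time of 48 h, tested at 10 uM; on this read-out lower numbers stand for less inhibition of growth and higher numbers for more inhibition of growth at the one concentration tested. Compound 1 `CC(=O)c1ccc(Nc2ccnc(SCC(=O)c3ccc(Br)cc3)n2)cc1` gives 10% in this assay. Compound 2 `CCOC(=O)c1ccc(Nc2ccnc(SCC(=O)c3ccc([N+](=O)[O-])cc3)n2)cc1` gives 26% in this assay, the higher of the two numbers, with compound 1 lying lower by a margin beyond the scatter. Compound 3 `CCOC(=O)c1ccc(Nc2ccnc(SCC(=O)c3ccc(C#N)cc3)n2)cc1` differs from compound 2 by cyano in place of nitro on an aromatic carbon. Within the data shown here, no measured pair isolates this change, so the size of the step is uncertain; a small fall or no step beyond the scatter is expected, namely a number 6 percentage points lower from compound 2 to compound 3 (within the scatter). Compound 3 is accordingly estimated at 20%, within a range from 5% to 38%.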

Compound 3, percent growth inhibition at one concentration: 28%
Beside the measured number, compound 3's estimate is 8 percentage points below it; the measured number falls inside the stated range.
By their numbers in this assay, from the lowest: compound 1; then compounds 2 and 3 (each within the scatter of the next).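

The exchange of cyano for nitro on the aromatic carbon para to a large group gives a number 2 percentage points higher from compound 2 to compound 3 (within the scatter) in this assay. At this position, then, the two groups cannot be told apart on this read-out, a point that compound 1 and compound 2 alone could not settle. No measurement at hand speaks to why they read alike. As far as these compounds go, what an amine or a carboxylic acid on this same carbon would give remains open, and so does whether a halogen such as chlorine would fall in line with nitro and cyano when the ethyl ester is kept.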